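A few compounds are considered here, and "the series" means these few. Any claim that something is new, unique, unknown or untested is made for them only; others in the source may bear on it.

Measured compounds: compound 1 `Cc1ccc2oc(-c3ccc(NC(=O)CN4CCN(CCCN(C)C)CC4)cc3)nc2c1` with 1810 nM in a functional assay on C6 cells (Rattus norvegicus) for cytotoxicity, read by MTT assay, with a stated time of 24 h; on this read-out lower numbers stand for stronger inhibition and higher numbers for weaker inhibition; compound 2 `Cc1cc(-c2nc3cc(Cl)ccc3o2)ccc1NC(=O)CCl`, for which this assay gives only a limit, > 100000 nM; compound 3 `CN(C)CCCN1CCN(CC(=O)Nc2ccc(-c3nc4cc(Cl)ccc4o3)cc2)CC1` with 910 nM.

Compound 2 sits at the limit of this assay, (the limit of > 100000 nM in this assay, at which 1 of the 3 values shown sits). Between compounds 3 and 1 the change is methyl in place of chloro on an aromatic carbon, and it makes a step of a 2.0-fold higher number from compound 3 to compound 1 (0.30 log units; within the scatter). Compound 4 `Cc1ccc2oc(-c3ccc(NC(=O)CCl)c(C)c3)nc2c1` has not yet been measured in this assay. It arises from compound 2 by methyl in place of chloro on an aromatic carbon, the same change as from compound 3 to compound 1. How the core of compound 2 differs from that of compound 3 is not broken down here.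

Compound 4 is therefore expected to move by about a step that the limit leaves unreadable from compound 2 to compound 4, resting on the step from compound 3 to compound 1 a 2.0-fold higher number from compound 3 to compound 1 (0.30 log units; within the scatter). Compound 4 is estimated at 150000 nM, most likely again reported only as a limit, within 30000 nM to 1000000 nM.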

Compound 4, half-maximal inhibitory concentration: 97600 nM
For compound 4 the middle estimate is 1.5-fold (0.19 log units) above the measured one; the range from low to high includes it.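

Compound 2 gives only a limit in this assay, not a number: the limit of > 100000 nM in this assay, at which 1 of the 4 values shown sits.

Methyl in place of chloro on an aromatic carbon gives an at least 1.0-fold lower number from compound 2 to compound 4 (0.01 log units; that floor lies within the scatter), so on this core the step can be read only as a floor. This does not show that the change carries over unaltered from one core to the other, nor that it behaves differently on each: the same change on two cores in this assay, a 2.0-fold higher number (0.30 log units; within the scatter) from compound 3 to compound 1 and an at least 1.0-fold lower number (0.01 log units; that floor lies within the scatter) from compound 2 to compound 4; the limit leaves it open whether they differ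

The compounds shown leave open how fluoro, methoxy or nitrile would read at the same aromatic carbon. They also leave open whether the change would read the same on a core carrying a simple amine chain in place of the chloroacetamide or the longer piperazine chain.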